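Buffer stability on going from compound 3 to compound 4

This account rests on a few compounds, and the source may have more. Where it says the series, first, only, none or still open, it means among the compounds named here.

In a physicochemical assay, read by HPLC, in phosphate buffer, with a stated time of 2 h, at pH 7.4 (on this read-out higher numbers stand for a more stable compound and lower numbers for a less stable compound), compound 1 `CC(C)COC(=O)N1CCN(C(=O)c2nc(Nc3cc(C4CC4)[nH]n3)c3cc(Cl)ccc3n2)C[C@H]1C` gives 99% while compound 2 `COC(=O)N1CCN(C(=O)c2nc(Nc3cc(C4CC4)[nH]n3)c3cc(Cl)ccc3n2)C[C@H]1C` gives 100% and compound 3 `CC(OC(=O)C(C)C)OC(=O)N1CCN(C(=O)c2nc(Nc3cc(C4CC4)[nH]n3)c3cc(Cl)ccc3n2)C[C@H]1C` gives 96.6% so that all three stand within the scatter of each other. Compound 4 `CCOC(=O)N1CCN(C(=O)c2nc(Nc3cc(C4CC4)[nH]n3)c3cc(Cl)ccc3n2)C[C@H]1C` carries hydrogen in place of (isopropylcarbonyl)oxy on a saturated chain carbon bound to an oxygen next to a carbonyl group and a saturated chain carbon which leaves ethoxy. The nearest evidence is a number 3.4 percentage points lower from compound 2 to compound 3 (within the scatter) together with a number 2.4 percentage points lower from compound 1 to compound 3 (within the scatter) and a number 1 percentage points higher from compound 1 to compound 2 (within the scatter) and each of these stays within the scatter. No step beyond the scatter is therefore expected in this assay and the expected size is a number 2.4 percentage points higher from compound 3 to compound 4 (within the scatter) as a small rise at most. For compound 4 the estimated value is 99% with an expected range from 94% to 100% as its limits.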

Compound 4, percent of the compound remaining: 97.7%
Estimate against measurement, compound 4: 1.3 percentage points above; the range from low to high includes it.
By their numbers in this assay, from the lowest: compounds 3, 4, 1 and 2 (each within the scatter of the next).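

Hydrogen in place of (isopropylcarbonyl)oxy on this saturated chain carbon gives a number 1.1 percentage points higher from compound 3 to compound 4 (within the scatter) in this assay, so compound 3 and its ethoxy counterpart cannot be told apart at this time point. Ethoxy also fits with the two simple chains: methyl in place of hydrogen gives a number 2.3 percentage points lower from compound 2 to compound 4 (within the scatter), and methyl in place of isopropyl gives a number 1.3 percentage points lower from compound 1 to compound 4 (within the scatter). Nothing at hand explains these readings. Going by these compounds, whether an amine or a carboxylic acid at this position would hold up equally in this assay stays open, as does a longer chain.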